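The source may report more compounds than this note shows. Statements on the series, on what has been measured and on what is new or still open speak of the compounds shown alone.

Working notes on the series. Compound 2 `N#Cc1ccc(-c2cc(COC(Cc3cn(C4CCN(Cc5ccc([N+](=O)[O-])cc5)CC4)nn3)c3ccc(Br)cc3)on2)cc1` carries 4-cyanophenyl on the shared core. In a functional assay on MDA-MB-231 cells (Homo sapiens) for cytotoxicity, with a stated time of 48 h (on this read-out lower numbers stand for stronger inhibition and higher numbers for weaker inhibition), compound 2 gives only a limit, > 25000 nM. Compound 1 `COc1ccc(-c2cc(COC(Cc3cn(C4CCN(Cc5ccc([N+](=O)[O-])cc5)CC4)nn3)c3ccc(Br)cc3)on2)cc1` likewise gives only a limit, > 25000 nM. Compound 3 `COc1cccc(-c2cc(COC(Cc3cn(C4CCN(Cc5ccc([N+](=O)[O-])cc5)CC4)nn3)c3ccc(Br)cc3)on2)c1` likewise gives only a limit, > 25000 nM. Within the data shown here, because of the limit of > 25000 nM in this assay, at which 3 of the 3 values shown sit, none of the measured steps can be read: a step that the two limits leave unreadable from compound 1 to compound 2, a step that the two limits leave unreadable from compound 1 to compound 3 and a step that the two limits leave unreadable from compound 2 to compound 3 all stay without size or direction. Compound 2 therefore stands at the limit together with the two other measured compounds, with no numerical footing within the series.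

Compound 4 `O=[N+]([O-])c1ccc(CN2CCC(n3cc(CC(OCc4cc(-c5ccccc5F)no4)c4ccc(Br)cc4)nn3)CC2)cc1` differs from compound 2 in one place: 2-fluorophenyl in place of 4-cyanophenyl on an aromatic carbon. Among the measured compounds shown here, the steps that bear on this change are the three unreadable ones just named; none of them gives a direction or a magnitude to work from. No step beyond the scatter can be expected in this assay on that basis. Compound 4 is therefore expected to give 40000 nM, with a range of 15000 nM to 150000 nM, most probably reported again as a limit. The estimated step is a step that the limit leaves unreadable from compound 2 to compound 4.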

Compound 4, half-maximal inhibitory concentration: 4000 nM
For compound 4 the middle estimate is 10-fold (1.00 log units) above the measured one, outside the stated range (below it).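

In this assay, 2-fluorophenyl in place of 4-cyanophenyl gives an at least 6.2-fold lower number from compound 2 to compound 4 (0.79 log units; beyond the scatter); in place of 3-methoxyphenyl it gives an at least 6.2-fold lower number from compound 3 to compound 4 (0.79 log units; beyond the scatter); and in place of 4-methoxyphenyl it gives an at least 6.2-fold lower number from compound 1 to compound 4 (0.79 log units; beyond the scatter). Among these compounds, the group on this aromatic carbon, next to the ring nitrogen, therefore bears on the read-out, which the earlier compounds, with their unreadable steps, could not show. Each of these sizes is only a lower bound on the true step: the limit of > 25000 nM in this assay, at which 3 of the 4 values shown sit.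

On these data alone, whether the change in compound 4 depends on the fluorine itself or on where it sits on the phenyl ring remains open. So does whether plain phenyl, 4-fluorophenyl or 2-chlorophenyl at this position would match compound 4 at 4000 nM.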